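Replacing the bromophenyl amide: compound 2 to compound 4

This account rests on a few compounds, and the source may have more. Where it says the series, first, only, none or still open, it means among the compounds named here.

In a functional assay on WI-38 VA13 cells (Homo sapiens) for cytotoxicity (a higher number here means that more compound is needed for the effect, a lower number that less compound is needed), compound 1 `O=C(Nc1ccc2nc(NC(=O)C3CCCCC3)sc2c1)c1ccccc1Oc1ccccc1` gives 0.1 ug/mL and compound 3 `O=C(Nc1ccc2nc(NC(=O)C3CCCCC3)sc2c1)c1c(F)cccc1C(F)(F)F` gives 0.032 ug/mL, both as measured numbers. Compound 2 `O=C(Nc1ccc2nc(NC(=O)C3CCCCC3)sc2c1)c1ccc(Br)cc1` reaches only a limit, > 4 ug/mL, not a number. Its standing on this series is therefore known no further than the limit of > 4 ug/mL in this assay, at which 1 of the 3 values shown sits. Compound 4 `Cc1coc(C)c1C(=O)Nc1ccc2nc(NC(=O)C3CCCCC3)sc2c1` differs from compound 2 by 2,4-dimethylfuran-3-yl in place of 4-bromophenyl on a carbonyl carbon. Among the compounds with values here, no measured pair isolates this change, so the step of an at least 10-fold lower number from compound 2 to compound 4 (1.00 log units; beyond the scatter) is expected rather than known, and it is expected to run downward out of the limit by more than the usual scatter. Compound 4 is estimated at 0.4 ug/mL, with a range from 0.06 ug/mL to 3 ug/mL.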

Compound 4, half-maximal effective concentration: 2.7 ug/mL
Beside the measured number, compound 4's estimate is 6.8-fold (0.83 log units) below it; low and high end bracket the measured number.
By their numbers in this assay, from the lowest: compound 3; then compound 1; then compound 4. At a limit, above all of these: compound 2.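

With 2,4-dimethylfuran-3-yl on the carbonyl carbon, compound 4 gives a measured 2.7 ug/mL in this assay, so a five-membered aromatic ring with a hetero atom at this position still yields a number, though a higher one than compound 1 at 0.1 ug/mL and compound 3 at 0.032 ug/mL. The replacement of 4-bromophenyl reads as an at least 1.4-fold lower number from compound 2 to compound 4 (0.17 log units; that floor lies within the scatter). Compound 2 remains a limit, so only a floor for this step can be read: the limit of > 4 ug/mL in this assay, at which 1 of the 4 values shown sits.

On these data alone, whether the ring oxygen or the two methyl groups set the number of compound 4 stays open. A pyridine ring or an aminophenyl group on this carbonyl carbon would also remain to be read.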